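The source may report more compounds than this note shows. Statements on the series, on what has been measured and on what is new or still open speak of the compounds shown alone.

Measured so far in an ADME assay on L6 cells (Rattus norvegicus) for cytotoxicity; a higher number here means a weaker inhibitor, a lower number a stronger inhibitor:

- compound 1, `O=C(NCCCn1ccnc1[N+](=O)[O-])c1ccc(C(F)(F)F)cc1`, gives 177000 nM
- compound 2, `O=C(NCCCn1ccnc1[N+](=O)[O-])c1ccc(OC(F)(F)F)cc1`, gives 274000 nM
- compound 3, `O=[N+]([O-])c1ncn(CCCCNS(=O)(=O)c2ccc(C(F)(F)F)cc2)n1`, gives 84900 nM

Compound 1 and compound 2 share one core and differ only by trifluoromethoxy in place of trifluoromethyl on an aromatic carbon. The step is a 1.5-fold higher number from compound 1 to compound 2 (0.19 log units; within the scatter). Compound 3 stands on a different core; the difference between the two cores is not broken down here. In this assay compound 3 gives the lowest of the three numbers, with compound 1 nearest and compound 2 furthest.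

Compound 4, `O=[N+]([O-])c1ncn(CCCCNS(=O)(=O)c2ccc(OC(F)(F)F)cc2)n1`, is not yet measured. It differs from compound 3 by trifluoromethoxy in place of trifluoromethyl on an aromatic carbon, the same change as between compound 1 and compound 2, at a place described in the same words. The expected step is a 1.4-fold higher number from compound 3 to compound 4 (0.15 log units; within the scatter), resting on the single earlier occurrence, which gave a 1.5-fold higher number from compound 1 to compound 2 (0.19 log units; within the scatter). For compound 4 the estimate in this assay is 120000 nM, expected to fall between 60000 nM and 250000 nM.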

Compound 4, half-maximal inhibitory concentration: 112000 nM
For compound 4 the middle estimate is 1.1-fold (0.03 log units) above the measured one; measured number inside the range.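

In this assay the exchange of trifluoromethyl for trifluoromethoxy gives a 1.3-fold higher number from compound 3 to compound 4 (0.12 log units; within the scatter), and its two occurrences agree: the same change on two cores in this assay, a 1.5-fold higher number (0.19 log units; within the scatter) from compound 1 to compound 2 and a 1.3-fold higher number (0.12 log units; within the scatter) from compound 3 to compound 4, 1.2-fold (0.07 log units) apart, within the scatter of two such steps. On these two cores, the change therefore carries over with a step of similar size, and neither step leaves the scatter. Two pairs do not show that this holds on any other core, and they give no reason for the agreement.

The compounds shown leave open how a nitrile, an amine or a carboxylic acid would read in place of trifluoromethyl on the aromatic carbon. From the compounds shown here alone, a longer chain on either core is also open, as is the separate share of each part in which the two cores differ.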